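The compounds below may be only part of what the source reports. "The series", "measured", "known", "first", "only" and "open" are said of these compounds alone.

The measured compounds, tested in a functional assay on the whole organism (strain Fischer 344) for inhibition, with Rattus norvegicus as the target, read by paw edema, at a dose of 0.01 mmol/kg by the intraperitoneal route; a lower number here means less inhibition, a higher number more inhibition at the dose given (going by the name of the read-out):

Compound 1 `COC(=O)c1c(O)c2ccccc2n(C)c1=O`: compound 1 gives 58.8%.
Compound 2 `Cn1c(=O)c(C(=O)NCCCCCCN)c(O)c2ccccc21`: compound 2 gives 68.5%.
Compound 3 `NCCCCCCNC(=O)c1c(O)c2ccccc2n(-c2ccccc2)c1=O`: compound 3 gives 68.8%.

Among these three numbers compound 2 stands second highest, with compound 3 nearest and compound 1 furthest, both within the scatter. Compound 4 `Cn1c(=O)c(C(=O)Nc2ccc(N)cc2)c(O)c2ccccc21` differs from compound 2 in one place: 4-aminophenyl in place of 6-aminohexyl on an amide-type nitrogen. Within the data shown here, the only measured step, a number 0.3 percentage points higher from compound 2 to compound 3 (within the scatter), alters a different place and stays within the scatter, so no step touches the amide-type nitrogen itself. With nothing pointing to a shift, no step beyond the scatter is expected in this assay for compound 4. Compound 4 is therefore estimated at 65%, within the range 48% to 80%. This estimate means an expected step of a number 3.5 percentage points lower from compound 2 to compound 4 (within the scatter).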

Compound 4, a percentage reported as inhibition, in the whole organism at one dose (the size of the read-out at that dose, not a potency): 69.5%
Compound 4: the middle estimate sits 4.5 percentage points below what was measured; the measured number falls inside the stated range.
By their numbers in this assay, from the lowest: compounds 1, 2, 3 and 4 (each within the scatter of the next, the first and the last beyond it).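

In this assay, among these compounds, the step of a number 1 percentage points higher from compound 2 to compound 4 (within the scatter) gives the first reading at the amide-type nitrogen, since the earlier step changed a different place. Here an open chain gives way to a six-membered aromatic ring of carbon only, with the same counts of heavy atoms, donors and acceptors, and the read-out stays within the scatter. Nothing available explains this result.

Still open, as far as these compounds go, is whether the amine in these groups matters. A plain phenyl or hexyl group, or a carboxylic acid in place of the amine, would test that.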